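The source may hold more compounds than are shown below. What is called first, only, known or untested is meant among the compounds shown, and "the series" means these compounds.

In an ADME assay on MT4 cells (Homo sapiens) for cytotoxicity (on this read-out lower numbers stand for higher toxicity in this test and higher numbers for lower toxicity in this test), compound 1 (`O=C(NC(=S)Nc1cccc(C(F)(F)F)c1)c1ccccc1`) reads > 100000 nM, which is a limit of the assay and not a number. Compound 2 (`CC[C@H]1CC[C@H](c2ccc(NC(=S)Nc3cccc(C(F)(F)F)c3)cc2)CC1`) gives 39000 nM. Among the compounds with values here, compound 3 (`FC(F)(F)c1cccc(NC(=S)Nc2ccc(I)cc2)c1`) gives 10000 nM, the lowest number so far in this assay. Compound 4 (`O=[N+]([O-])c1ccc(NC(=S)Nc2cccc(C(F)(F)F)c2)cc1`) has nitro in place of iodo on an aromatic carbon, para to a large group: nitro in place of iodo on an aromatic carbon. Within the data shown here, only one measured step bears on this change, since iodo also enters there: a 3.9-fold lower number from compound 2 to compound 3 (0.59 log units; beyond the scatter), with iodo in place of 4-ethylcyclohexyl. Among the measured compounds shown here, no measured compound carries nitro, so that modest step gives only a rough guide to size. The expected change is a 1.5-fold higher number from compound 3 to compound 4 (0.18 log units; within the scatter), with no clear shift in either direction expected. For compound 4 the estimate is 15000 nM, with an expected range of 5000 nM to 50000 nM.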

Compound 4, half-maximal cytotoxic concentration: 9200 nM
Compound 4: the middle estimate sits 1.6-fold (0.21 log units) above what was measured; measured number inside the range.
By their numbers in this assay, from the lowest: compounds 4 and 3 (each within the scatter of the next); then compound 2. At a limit, above all of these: compound 1.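

In this assay the swap of iodo for nitro, on the aromatic carbon para to a large group, gives a 1.1-fold lower number from compound 3 to compound 4 (0.04 log units; within the scatter) and so the read-out does not separate these two groups at this position. Nitro in place of 4-ethylcyclohexyl gives a 4.2-fold lower number from compound 2 to compound 4 (0.63 log units; beyond the scatter) and so the gap to compound 2 seen with iodo recurs with a second, different group.

As far as these compounds go, whether an amine or a carboxylic acid here would stay level with compound 3 and compound 4 remains open. No measurement shown bears on why these two groups read alike.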